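This account rests on a few compounds, and the source may have more. Where it says the series, first, only, none or still open, it means among the compounds named here.

Measured compounds in the series:
compound 1, `N#CC1=C(N)OC(c2c[nH]c3ccccc23)=C(C#N)C1c1ccccc1Cl`, 10.4%
compound 2, `N#CC1=C(N)OC(c2c[nH]c3ccccc23)=C(C#N)C1c1ccccc1F`, "not active" (no number reported)
compound 3, `COc1cc(Br)c(C2C(C#N)=C(N)OC(c3c[nH]c4ccccc34)=C2C#N)cc1OC`, 20.5%

All three were tested in a functional assay, tested at 100 ug/mL; a higher number here means a stronger effect of the compound at the concentration tested, a lower number a weaker effect. Compound 1 gives 10.4%, compound 3 gives 20.5%, and for compound 2 only "not active" (no number reported) is reported, with no single number. Among the two numbers, compound 1 stands lowest; the nearest is compound 3, whose value lies higher by more than the usual scatter. For the measured compounds named here, no step between two measured compounds differing in one place is available, so the effect of a change on the saturated ring carbon cannot be read from a comparison.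

Compound 4, `Cc1ccc(C2C(C#N)=C(N)OC(c3c[nH]c4ccccc34)=C2C#N)cc1`, is not yet measured in this assay. It differs from compound 1 as follows: 4-methylphenyl in place of 2-chlorophenyl on a saturated ring carbon. Going by the values given here, no comparable step is at hand, and so the estimated step is only a number 3.6 percentage points higher from compound 1 to compound 4 (within the scatter), which is not beyond the scatter. For compound 4 the expected value is 14%, with a range from 0% to 32%.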

Compound 4, a percentage reported as activity, at one concentration (the size of the read-out at that concentration, not a potency): 5.5%
Compound 4: the middle estimate sits 8.5 percentage points above what was measured; low and high end bracket the measured number.
By their numbers in this assay, from the lowest: compounds 4 and 1 (each within the scatter of the next); then compound 3.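

In this assay, the saturated ring carbon now has its first readable step: 4-methylphenyl in place of 2-chlorophenyl gives a number 4.9 percentage points lower from compound 1 to compound 4 (within the scatter). This position therefore accepts an exchange of one aryl group for another with the same heavy-atom count, with chlorine leaving and a methyl group entering, without a change beyond the scatter, and neither group can be ranked above the other. Nothing available here speaks to a reason for this result.

From the compounds shown here alone, the step changes the substituent and its place on the phenyl ring together, so what an unsubstituted phenyl or a 4-chlorophenyl would give at this carbon remains open. Also open, going by these compounds, is whether a pyridine ring, or a phenyl carrying an amine or a carboxylic acid, would move the read-out beyond the scatter.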